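Removing the Nitro Group From Two Related Cores

This account rests on a few compounds, and the source may have more. Where it says the series, first, only, none or still open, it means among the compounds named here.

Compound 1 `O=[N+]([O-])c1ccc(COc2ccc(Nc3ncnc4cc5c(cc34)OCCOCCOCCOCCO5)cc2)cc1` and compound 2 `O=[N+]([O-])c1ccc(COc2cccc(Nc3ncnc4cc5c(cc34)OCCOCCO5)c2)cc1` are built on cores whose difference is not broken down here. In a functional assay on DU-145 cells (Homo sapiens) for antiproliferative activity, read by MTT assay, with a stated time of 72 h (on this read-out lower numbers stand for stronger inhibition and higher numbers for weaker inhibition), compound 1 gives > 100000 nM, which is a limit of the assay rather than a number. In this assay compound 2 gives > 100000 nM, also a limit. Compound 3 `c1ccc(COc2cccc(Nc3ncnc4cc5c(cc34)OCCOCCO5)c2)cc1` comes from compound 2 by one change, (hydrogen in place of nitro on an aromatic carbon). In this assay compound 3 gives > 100000 nM, again a limit. The step that the two limits leave unreadable from compound 2 to compound 3 cannot be sized because of the limit of > 100000 nM in this assay, at which 3 of the 3 values shown sit. Compound 4 `c1ccc(COc2ccc(Nc3ncnc4cc5c(cc34)OCCOCCOCCOCCO5)cc2)cc1` carries the same change from compound 1, (hydrogen in place of nitro on an aromatic carbon). Resting only on compound 1 and its limit > 100000 nM, compound 4 is expected to remain at that limit. The step that the limit leaves unreadable from compound 1 to compound 4 is thus an estimate rather than a measurement. Compound 4 is estimated at 200000 nM, expected between 60000 nM and 1000000 nM.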

Compound 4, half-maximal inhibitory concentration: 8800 nM
Compound 4: middle estimate off by 23-fold (1.36 log units), on the high side; measured number outside the range, below it.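

In this assay, hydrogen in place of nitro on the core of compound 1 gives an at least 11-fold lower number from compound 1 to compound 4 (1.05 log units; beyond the scatter), and this step starts from a limit of the assay rather than a number. On this one core, then, removing the nitro group goes with stronger inhibition, and compound 4 gives a measured number. This does not show that the change carries from one core to another, since the same step on the core of compound 2 cannot be read, because compound 2 and compound 3 both sit at a limit: the limit of > 100000 nM in this assay, at which 3 of the 4 values shown sit.

As far as these compounds go, it remains open whether an amine or a carboxylic acid in place of the nitro group would also give a measured number. From the compounds shown here alone, compound 3 and compound 4 differ in more than one place, so what their different cores contribute also stays open.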